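A few compounds are considered here, and "the series" means these few. Any claim that something is new, unique, unknown or untested is made for them only; others in the source may bear on it.

Compound 1 `Cc1ccc(C2=NN(c3ccc([N+](=O)[O-])cc3)C(c3cn(-c4ccccc4)nc3-c3ccc(Cl)c(Cl)c3)C2)cc1` gives 72.5% in a functional assay on the whole organism (strain Wistar) for inhibition, with Rattus norvegicus as the target, read by paw edema, with stated times of 30 min and 60 min, at a dose of 50 mg/kg by the oral route; a higher number here means more inhibition at the dose given (going by the name of the read-out), a lower number less inhibition.
Compound 2 `O=CN1N=C(c2ccc(F)cc2)CC1c1cn(-c2ccccc2)nc1-c1ccc(Cl)c(Cl)c1` gives 56.5% in this assay.

Of the two compounds measured in this assay, compound 1 stands highest. Within the data shown here, its only companion is compound 2, whose result lies lower by a gap that goes beyond the usual scatter, though the two structures differ in more than one place and no single step joins them.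

Compound 3 `Cc1ccc(C2=NNC(c3cn(-c4ccccc4)nc3-c3ccc(Cl)c(Cl)c3)C2)cc1` has not yet been measured. It differs from compound 1 in one place: hydrogen in place of 4-nitrophenyl on an amine nitrogen in a ring. Among the measured compounds shown here, no pair of measured compounds isolates this change, so the expectation rests on the standing of compound 1 alone. Because compound 1 reaches 72.5% with the 4-nitrophenyl group present, the removal of that group is expected to lower the result, and the expected step is a number 17.5 percentage points lower from compound 1 to compound 3 (beyond the scatter), a fall beyond the scatter rather than none. Compound 3 is therefore estimated at 55% in this assay, with a range from 40% to 68%.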

Compound 3, a percentage reported as inhibition, in the whole organism at one dose (the size of the read-out at that dose, not a potency): 56.5%
For compound 3 the middle estimate is 1.5 percentage points below the measured one; the measured number falls inside the stated range.
By their numbers in this assay, from the lowest: compounds 2 and 3 (each within the scatter of the next); then compound 1.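

In this assay, replacing the 4-nitrophenyl group on the amine nitrogen in a ring with hydrogen gives a number 16 percentage points lower from compound 1 to compound 3 (beyond the scatter). Among these compounds, this is the first direct reading at this position: the group carries a measurable part of the result, yet it is not needed for inhibition, since compound 3 with only hydrogen there still gives 56.5%. No measurement shown here accounts for the step.

The compounds shown leave open whether the gain belongs to the phenyl ring itself or to its nitro group, which a plain phenyl or a 4-aminophenyl group at the same nitrogen would separate. They also leave open how an acetyl group or a short alkyl chain would fare there, and a single dose says nothing of potency.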